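The source may hold more compounds than are shown below. What is called first, only, known or untested is meant among the compounds shown, and "the series" means these compounds.

Two members of the series have been run in an ADME assay (MDM cells, Homo sapiens) for cytotoxicity, read by resazurin assay, with a stated time of 3 days (on this read-out higher numbers stand for weaker inhibition and lower numbers for stronger inhibition), and both carry the same core with a butylthio chain. Compound 1 `CCCCSc1nnc(COc2ccccc2C2=NOC(c3ccc(Cl)cc3Cl)C2)n1NC(=O)c1ccccc1` gives 2.5 ug/mL, the lowest of the two numbers recorded so far. Compound 2 `CCCCSc1nnc(COc2ccccc2C2=NOC(c3ccc(Cl)cc3Cl)C2)n1NC(=O)CCl` differs from compound 1 only in the acyl part. In this assay compound 2 gives 2.8 ug/mL. The step of a 1.1-fold higher number from compound 1 to compound 2 (0.05 log units; within the scatter) lies within the scatter, so the two compounds read as equal on this assay.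

The next compound, compound 3 `CCCSc1nnc(COc2ccccc2C2=NOC(c3ccc(Cl)cc3Cl)C2)n1NC(=O)c1ccccc1`, keeps the benzoyl group of compound 1 and alters the sulfur-bound chain: hydrogen in place of methyl on a saturated chain carbon, three bonds along the chain from a sulfur. Within the data shown here, no measured step touches this chain, so the step from compound 1 to compound 2 bears on it only indirectly, showing that a change elsewhere in the molecule left the read-out unmoved. Nothing in the measured pair points to a shift in either direction for a shortened chain, and the expected step of no change at the digits printed from compound 1 to compound 3 (within the scatter) is therefore no larger than the scatter. Compound 3 is thus expected to give about 2.5 ug/mL in this assay, with a likely range from 1.2 ug/mL to 5.5 ug/mL.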

Compound 3, half-maximal inhibitory concentration: 14.8 ug/mL
The estimate for compound 3 lay 5.9-fold (0.77 log units) below the measured number; the whole stated range lies below it.
By their numbers in this assay, from the lowest: compounds 1 and 2 (each within the scatter of the next); then compound 3.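

Among these compounds, the sulfur-bound chain is the first place where a single change moves the read-out: in this assay, butyl to propyl gives [ a 5.9-fold higher number from compound 1 to compound 3 (0.77 log units; beyond the scatter) ], towards weaker inhibition. The acyl change in [ a 1.1-fold higher number from compound 1 to compound 2 (0.05 log units; within the scatter) ] left the number within the scatter, so for these three compounds the read-out responds to the chain on sulfur and not to the swap of phenyl for chloromethyl on the carbonyl carbon. The loss of a single methyl, 1 heavy atom with no ring, hydrogen-bond donor, hydrogen-bond acceptor or charge involved, is enough for this step, and nothing available accounts for its size.

On these data alone, whether a pentyl or longer chain on sulfur would bring the number lower still, or whether an ethyl chain would raise it further, remains open, as the position rests on one step. It also remains open whether the same shortening would give a step of similar size with the chloromethyl carbonyl of compound 2, since the step is shown only with the benzoyl group in place.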